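Removing one fluoro from compound 1

The compounds below may be only part of what the source reports. "The series", "measured", "known", "first", "only" and "open" are said of these compounds alone.

Values in a functional assay on CCRF-CEM cells (Homo sapiens) for cytotoxicity, in the absence of a further agent; on this read-out higher numbers stand for weaker inhibition and lower numbers for stronger inhibition:
Compound 1 `COC(=O)c1ccc(CN(CCCc2c(N)nc(N)nc2O)c2cc(F)cc(F)c2[N+](=O)[O-])cc1` gives > 100000 nM, a limit.
Compound 2 `Nc1nc(N)c(CCCN(Cc2ccc(NC(CCC(=O)O)C(=O)O)cc2)c2cc(F)c(F)cc2[N+](=O)[O-])c(O)n1` gives > 100000 nM, a limit.
Compound 3 `Nc1nc(N)c(CCCN(Cc2ccc(NC(CCC(=O)O)C(=O)O)cc2)c2cc(F)cc(F)c2[N+](=O)[O-])c(O)n1` gives > 100000 nM, a limit.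

Compound 1 has no number in this assay and stands at the limit of > 100000 nM in this assay, at which 3 of the 3 values shown sit. Compound 4 `COC(=O)c1ccc(CN(CCCc2c(N)nc(N)nc2O)c2cc(F)ccc2[N+](=O)[O-])cc1`, not yet measured, differs from compound 1 by hydrogen in place of fluoro on an aromatic carbon, with hydrogen in place of fluoro on an aromatic carbon. The closest measured change, 3,5-difluoro-2-nitrophenyl in place of 4,5-difluoro-2-nitrophenyl, is a step that the two limits leave unreadable from compound 2 to compound 3. The other measured change is a step that the two limits leave unreadable from compound 1 to compound 3. Neither gives a size to carry over, so no step beyond the scatter is expected, and compound 4 will probably also reach the limit. The expected change is a number no higher from compound 1 to compound 4 (the limit leaves the size open). For compound 4 the estimated value is 100000 nM, within an expected range from 40000 nM to 200000 nM.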

Compound 4, half-maximal inhibitory concentration: 55000 nM
The estimate for compound 4 lay 1.8-fold (0.26 log units) above the measured number; the range from low to high includes it.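

In this assay, hydrogen in place of the fluoro ortho to a nitro group gives the only readable step among the compounds shown: an at least 1.8-fold lower number from compound 1 to compound 4 (0.25 log units; that floor lies within the scatter). Since that floor lies within the scatter, the step shows only that this position can yield a number, not how large the change is. The other steps cannot be read, and compound 4 alone sits off the limit: the limit of > 100000 nM in this assay, at which 3 of the 4 values shown sit.

As far as these compounds go, the true size of the step stays open, as does whether chloro or methoxy at this position would also give a number. So does whether the same change gives a number on compound 3, with its (1,3-dicarboxypropyl)amino group.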